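A few compounds are considered here, and "the series" means these few. Any claim that something is new, unique, unknown or untested is made for them only; others in the source may bear on it.

Measured compounds and their values:
Compound 1, `O=S(=O)(c1ccc(F)cc1)c1cn(C2CCNC2)c2ncccc12`, gives 50% in a functional assay on HeLa cells for agonist activity at 5-hydroxytryptamine receptor 6 (Homo sapiens), read by cAMP accumulation and immunoassay; on this read-out higher numbers stand for larger maximal responses and lower numbers for smaller maximal responses.
Compound 2, `CN1CCC(n2cc(S(=O)(=O)c3ccccc3)c3cccnc32)C1`, gives 61% in this assay.
Compound 3, `CN1CCC(n2cc(S(=O)(=O)c3cccc(F)c3)c3cccnc32)C1`, gives 54% in this assay.

Among these three numbers compound 2 stands highest. The nearest is a number 7 percentage points lower from compound 2 to compound 3 (within the scatter), a gap within the scatter, so the two cannot be told apart. For the measured compounds named here, the furthest is that of compound 1, whose value lies beyond the scatter below that of compound 2; compound 1 differs from compound 2 in two places at once, so no single step links them.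

Compound 4, `O=S(=O)(c1ccccc1)c1cn(C2CCCNC2)c2ncccc12`, has not been measured. It differs from compound 2 in one place: piperidin-3-yl in place of 1-methylpyrrolidin-3-yl on an aromatic nitrogen. Going by the values given here, only one measured step is known, and it concerns a fluoro in place of hydrogen on an aromatic carbon, a change of a different kind at a different place; its size, a number 7 percentage points lower from compound 2 to compound 3 (within the scatter), stayed within the scatter. Among the compounds with values here, no measured step changes the ring on the aromatic nitrogen, so there is no basis for expecting a move beyond the scatter in this assay in either direction. Compound 4 is therefore expected to give 55%, with a range from 40% to 72%. This estimate means a step of a number 6 percentage points lower from compound 2 to compound 4 (within the scatter), expected to stay within the scatter.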

Compound 4, largest response reached (Emax), in percent of the reference or control that the assay uses: 56%
Compound 4: middle estimate off by 1 percentage points, on the low side; the range from low to high includes it.
By their numbers in this assay, from the lowest: compounds 1, 3, 4 and 2 (each within the scatter of the next, the first and the last beyond it).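

For the compounds shown here, this is the first measured change on the aromatic nitrogen, and it alters two features at once: the five-membered ring becomes a six-membered one, and the 1-methyl group gives way to a ring amine with a hydrogen-bond donor, while the count of heavy atoms stays the same. In this assay the result is a number 5 percentage points lower from compound 2 to compound 4 (within the scatter) and so this combined change leaves the maximal response indistinguishable from that of the parent, which shows that this position can accept a piperidin-3-yl in place of a 1-methylpyrrolidin-3-yl without a measurable loss on this read-out. Nothing available explains this outcome, and a single step cannot show whether ring size and the methyl group each have no effect or have effects that offset each other.

A 1-methylpiperidin-3-yl group would keep the six-membered ring together with the methyl and so help separate those two features. A piperidin-4-yl group or an open 2-aminoethyl chain on the same nitrogen would test whether the response holds when the amine sits differently or the ring is absent altogether.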